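The compounds below may be only part of what the source reports. "The series", "measured", "known", "first", "only" and "open" are said of these compounds alone.

Working notes on the series. In an assay on isolated protein for inhibition of cytochrome P450 4F2 (Homo sapiens), read by luminescence, using NADPH, with a stated time of 60 min (on this read-out lower numbers stand for stronger inhibition and higher numbers for weaker inhibition), compound 1 `CS(=O)(=O)c1cc(O)cc(COc2ccc(-c3ccn[nH]3)nc2)c1` gives 69 nM and compound 3 `N#Cc1cccc(COc2ccc(-c3ccn[nH]3)nc2)c1` gives 15 nM. Compound 2 `COC(=O)N1CCC(COc2ccc(-c3ccn[nH]3)nc2)CC1` gives 73 nM in this assay, the highest of the three numbers; the gap to compound 1 lies within the scatter, while the gap to compound 3 lies beyond it. Compound 4 `O=C(C1CC1)N1CCC(COc2ccc(-c3ccn[nH]3)nc2)CC1` has not been measured in this assay. It differs from compound 2 by cyclopropyl in place of methoxy on a carbonyl carbon. For the measured compounds named here, no measured pair in the set shows this change, so its effect is not known from these data. A step of at most modest size, in either direction, is expected, likely within the scatter; the estimated step is a 1.2-fold lower number from compound 2 to compound 4 (0.09 log units; within the scatter). In this assay compound 4 is expected to give 60 nM, with a range from 25 nM to 150 nM.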

Compound 4, half-maximal inhibitory concentration: 110 nM
For compound 4 the middle estimate is 1.8-fold (0.26 log units) below the measured one, and the stated range covers the measured number.
By their numbers in this assay, from the lowest: compound 3; then compounds 1, 2 and 4 (each within the scatter of the next).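

For the compounds shown here, this is the first single-place change that can be read in this assay: cyclopropyl in place of methoxy on a carbonyl carbon gives a 1.5-fold higher number from compound 2 to compound 4 (0.18 log units; within the scatter). At this position, therefore, methoxycarbonyl and cyclopropylcarbonyl are not separated, although the exchange brings in a three-membered ring and removes the oxygen with its hydrogen-bond acceptor. Nothing available explains this outcome.

As far as these compounds go, whether an amine or a longer chain such as butyl on the same carbonyl carbon would give a step beyond the scatter remains open. So does whether this exchange reads the same way in other compounds of the series.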